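Adding a second chloro to the N-aryl ring of compound 1

The source may report more compounds than this note shows. Statements on the series, on what has been measured and on what is new or still open speak of the compounds shown alone.

Of the compounds shown here, three sharing one core have been measured in a functional assay on PC-12 cells (Rattus norvegicus) for cytotoxicity, read by MTT assay, with stated times of 2 h and 24 h, tested at 5 uM; a higher number here means a stronger effect of the compound at the concentration tested, a lower number a weaker effect. Compound 1 `Oc1cc(C(F)(F)F)ccc1-c1nc(-c2ccccc2O)n(-c2ccc(Cl)cc2)n1` gives 87.3%. Compound 2 `N#Cc1ccc(-n2nc(-c3ccc(C(F)(F)F)cc3O)nc2-c2ccccc2O)cc1` gives 86.8%, and compound 3 `Cc1ccc(-n2nc(-c3ccc(C(F)(F)F)cc3O)nc2-c2ccccc2O)c(C)c1` gives 93.3%. Compound 1 holds the second highest of the three numbers, but the spread is small: the step of a number 0.5 percentage points lower from compound 1 to compound 2 (within the scatter) and the step of a number 6 percentage points higher from compound 1 to compound 3 (within the scatter) both fall within the scatter, as does the step of a number 6.5 percentage points higher from compound 2 to compound 3 (within the scatter). On these numbers the three compounds cannot be told apart.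

The new compound 4 `Oc1cc(C(F)(F)F)ccc1-c1nc(-c2ccccc2O)n(-c2ccc(Cl)cc2Cl)n1` differs from compound 1 in one place: chloro in place of hydrogen on an aromatic carbon. Among the compounds with values here, two measured steps bear on this change. Both alter the same aryl group on the ring nitrogen. The step of a number 0.5 percentage points lower from compound 1 to compound 2 (within the scatter) swaps one group for another at that ring, and the step of a number 6 percentage points higher from compound 1 to compound 3 (within the scatter) rebuilds its substitution pattern, yet neither moves the read-out beyond the scatter. Adding a chloro to that ring is therefore expected to leave the read-out essentially unchanged, with no step beyond the scatter in either direction.

Compound 4 is estimated at 88%, with a range from 78% to 96%, meaning an expected step of a number 0.7 percentage points higher from compound 1 to compound 4 (within the scatter).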

Compound 4, a percentage reported as activity, at one concentration (the size of the read-out at that concentration, not a potency): 86.7%
Compound 4: middle estimate off by 1.3 percentage points, on the high side; the measured number falls inside the stated range.
By their numbers in this assay, from the lowest: compounds 4, 2, 1 and 3 (each within the scatter of the next).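

In this assay, putting a second chloro on the N-aryl ring, ortho to a large group and meta to the existing chloro group, gives a step of a number 0.6 percentage points lower from compound 1 to compound 4 (within the scatter) and so leaves the read-out where it was. The earlier steps shown here swapped or rebuilt the substituents on this ring, whereas this one adds a single atom while keeping the original chloro, and even this direct test shows no effect beyond the scatter. The 2,4-dichlorophenyl group also cannot be told apart from its two other neighbours, with a number 6.6 percentage points lower from compound 3 to compound 4 (within the scatter) and a number 0.1 percentage points lower from compound 2 to compound 4 (within the scatter), so all four aryl groups behave alike here, and nothing available explains these numbers.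

It remains open whether this ring position matters at all, since an amine, a carboxylic acid or a longer chain on the same carbon would differ far more from chloro than any group shown so far. The two hydroxy groups and the trifluoromethyl group, which all four compounds share, also leave open how much of the read-out depends on the shared core rather than on the N-aryl ring.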